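Benzylamino in Place of Isopropoxy on the Shared Core

This account rests on a few compounds, and the source may have more. Where it says the series, first, only, none or still open, it means among the compounds named here.

The series rests on a shared five-membered core, seen in compound 1 `CC(C)OC1=C(C(=O)c2ccccc2)C(c2ccc(Br)cc2)N(CCCn2ccnc2)C1=O`, which in a functional assay on NCI-H1299 cells (Homo sapiens) for antiproliferative activity, read by MTT assay, with a stated time of 72 h (on this read-out lower numbers stand for stronger inhibition and higher numbers for weaker inhibition), gives 18900 nM. Going by the values given here, compound 1 stands second highest among the three numbers so far: its nearest neighbour is compound 2 `O=C(C1=C(OC2CCCCC2)C(=O)N(CCCn2ccnc2)C1c1ccc(Br)cc1)c1ccccc1`, with 19900 nM, and a 1.1-fold higher number from compound 1 to compound 2 (0.02 log units; within the scatter). Compound 3 `O=C(C1=C(Nc2ccccc2Br)C(=O)N(CCCn2ccnc2)C1c1ccc(Br)cc1)c1ccccc1` gives 15600 nM, and a 1.2-fold lower number from compound 1 to compound 3 (0.08 log units; within the scatter); likewise a 1.3-fold lower number from compound 2 to compound 3 (0.11 log units; within the scatter). All three numbers thus sit together within the scatter, and none of them can be called stronger or weaker than another.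

Compound 4 `O=C(C1=C(NCc2ccccc2)C(=O)N(CCCn2ccnc2)C1c1ccc(Br)cc1)c1ccccc1` is the next step from compound 1: benzylamino in place of isopropoxy on a double-bonded ring carbon. Among the compounds with values here, the steps that bear on it are the move from compound 1 to compound 3 and from compound 2 to compound 3, in which an amino-type group took the place of an alkoxy group on the same ring carbon; both stayed within the scatter. On that basis no step beyond the scatter is expected in this assay, and compound 4 is estimated at 16000 nM, with a range from 7000 nM to 36000 nM. The expected step is a 1.2-fold lower number from compound 1 to compound 4 (0.07 log units; within the scatter).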

Compound 4, half-maximal inhibitory concentration: 25300 nM
The estimate for compound 4 lay 1.6-fold (0.20 log units) below the measured number, within the range that was stated.
By their numbers in this assay, from the lowest: compounds 3, 1, 2 and 4 (each within the scatter of the next).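

In this assay, benzylamino at this double-bonded ring carbon brings one six-membered aromatic ring of carbon only and a hydrogen-bond donor, yet the step from isopropoxy stays within the scatter (a 1.3-fold higher number from compound 1 to compound 4 (0.13 log units; within the scatter)), as does the step from cyclohexyloxy (a 1.3-fold higher number from compound 2 to compound 4 (0.10 log units; within the scatter)). Benzyl in place of 2-bromophenyl on the amine nitrogen also stays within the scatter (a 1.6-fold higher number from compound 3 to compound 4 (0.21 log units; within the scatter)), so the four groups shown at this position cannot be told apart in this read-out. No measurement shown here accounts for these numbers.

From the compounds shown here alone, what a morpholine or a carboxylic acid would do on this ring carbon remains open. So does whether a shorter chain in place of the 3-(1H-imidazol-1-yl)propyl group, or a chlorine in place of the bromine of the 4-bromophenyl group, would move the number beyond the scatter.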